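Swapping a naphthyl ether for a fluorophenyl ether

The source may report more compounds than this note shows. Statements on the series, on what has been measured and on what is new or still open speak of the compounds shown alone.

Measured compounds:
compound 1, `O=c1c2ccccc2nc(-c2ccccc2)n1/N=C/c1ccc(Oc2ccc(Br)cc2)cc1`, 6.39
compound 2, `O=c1c2ccccc2nc(-c2ccccc2)n1/N=C/c1ccc(Oc2ccc3ccccc3c2)cc1`, 6.53

Both compounds share one core and differ only in the ring carried by the ether oxygen. In a physicochemical assay for lipophilicity, in phosphate buffer, measured as octanol-water partition (on this read-out higher numbers stand for higher lipophilicity and lower numbers for lower lipophilicity), compound 1 gives 6.39, and compound 2 gives 6.53. Among the compounds with values here, the single measured step, a number 0.14 log units higher from compound 1 to compound 2 (within the scatter), is too small to read as a real difference, so on the numbers at hand compound 2 stands within the scatter of compound 1 rather than clearly above it.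

Compound 3, `O=c1c2ccccc2nc(-c2ccccc2)n1/N=C/c1ccc(Oc2ccc(F)cc2)cc1`, has not yet been measured. Its change from compound 2 is 4-fluorophenyl in place of naphthalen-2-yl on an oxygen on an aromatic ring. Within the data shown here, no measured step covers this exact swap; the one step that touches the same position, a number 0.14 log units higher from compound 1 to compound 2 (within the scatter), shows that trading a bromophenyl for a naphthyl barely moved this assay. Removing the second fused ring and placing a fluorine where the bromine sat in compound 1 is expected to lower the number, and the estimated step is a number 0.93 log units lower from compound 2 to compound 3 (beyond the scatter). Compound 3 is therefore expected to give about 5.6, with a range from 5.1 to 6.1.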

Compound 3, partition coefficient: 6.21
Beside the measured number, compound 3's estimate is 0.61 log units below it; the whole stated range lies below it.
By their numbers in this assay, from the lowest: compounds 3, 1 and 2 (each within the scatter of the next, the first and the last beyond it).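

In this assay, this position on the ether oxygen now gives its first step beyond the scatter: 4-fluorophenyl in place of naphthalen-2-yl gives a number 0.32 log units lower from compound 2 to compound 3 (beyond the scatter), a modest change that separates only these two ends of the series, since compound 1 lies within the scatter of both. The other new comparison isolates the halogen, as fluoro in place of bromo on an aromatic carbon gives a number 0.18 log units lower from compound 1 to compound 3 (within the scatter) and leaves compound 1 and compound 3 indistinguishable on this read-out. No supporting measurement here explains the size of either step.

As far as these compounds go, all three groups on the oxygen are aromatic carbon rings, so it remains open how a plain phenyl without a halogen, or a phenyl carrying an amine or a carboxylic acid, would compare in this assay. A simple methyl or a longer carbon chain on the same oxygen, with no ring at all, would also test whether the pattern in these three compounds extends beyond aromatic groups.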